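The source may report more compounds than this note shows. Statements on the series, on what has been measured and on what is new or still open speak of the compounds shown alone.

Compound 2 `COc1ccc(Cn2c(CCc3ccccc3)nnc2[C@H](NC(=O)c2ccccn2)c2c[nH]c3ccccc23)cc1`, compound 1 `CCc1ccc(Cn2c(CCc3ccccc3)nnc2[C@H](NC(=O)c2ccccn2)c2c[nH]c3ccccc23)cc1` and compound 3 `COc1ccc(Cn2c(CCc3ccccc3)nnc2[C@H](NC(=O)c2cnccn2)c2c[nH]c3ccccc23)cc1` share one core and were tested in an in vitro assay on LLC-PK1 cells for displacement of a labelled ligand from growth hormone secretagogue receptor type 1 (Homo sapiens); a higher number here means a weaker inhibitor, a lower number a stronger inhibitor. Compound 2 gives 0.7 nM in this assay, compound 1 gives 67 nM, and compound 3 gives 14 nM. The change ethyl in place of methoxy on an aromatic carbon brings a 96-fold higher number from compound 2 to compound 1 (1.98 log units; beyond the scatter), and the change pyrazin-2-yl in place of pyridin-2-yl on a carbonyl carbon brings a 20-fold higher number from compound 2 to compound 3 (1.30 log units; beyond the scatter). Compound 4 `CCc1ccc(Cn2c(CCc3ccccc3)nnc2[C@H](NC(=O)c2cnccn2)c2c[nH]c3ccccc23)cc1` has not yet been measured. It differs from compound 3 by ethyl in place of methoxy on an aromatic carbon, the same change that separates compound 2 from compound 1, while the two cores differ as pyrazin-2-yl in place of pyridin-2-yl on a carbonyl carbon. If this change acts on the core of compound 3 as it did on the core of compound 2, a step of about the size of a 96-fold higher number from compound 2 to compound 1 (1.98 log units; beyond the scatter) is expected. The change has been seen only once, so a somewhat smaller expected step is used. Compound 4 is expected to show a 64-fold higher number from compound 3 to compound 4 (1.81 log units; beyond the scatter) in this assay. Compound 4 is therefore estimated at 900 nM, between 250 nM and 3500 nM.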

Compound 4, half-maximal inhibitory concentration: 89 nM
Compound 4: middle estimate off by 10-fold (1.00 log units), on the high side; the measured number lies below the stated range.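

In this assay, ethyl in place of methoxy gives a 6.4-fold higher number from compound 3 to compound 4 (0.80 log units; beyond the scatter), so the direction of the change carries over to the core of compound 3, but its size does not: the same change on two cores in this assay, a 96-fold higher number (1.98 log units; beyond the scatter) from compound 2 to compound 1 and a 6.4-fold higher number (0.80 log units; beyond the scatter) from compound 3 to compound 4, 15-fold (1.18 log units) apart, beyond the scatter of two such steps. With ethyl present, pyrazin-2-yl in place of pyridin-2-yl gives a 1.3-fold higher number from compound 1 to compound 4 (0.12 log units; within the scatter), so the two changes do not simply add: the same change on two cores in this assay, a 20-fold higher number (1.30 log units; beyond the scatter) from compound 2 to compound 3 and a 1.3-fold higher number (0.12 log units; within the scatter) from compound 1 to compound 4, 15-fold (1.18 log units) apart, beyond the scatter of two such steps. These two pairs of steps show that a step measured on one core was a poor guide to its size on the other, but they do not show why the sizes differ.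

From the compounds shown here alone, it remains open how a hydroxyl, a chlorine or a longer chain such as propyl would behave in place of methoxy on these two cores. Going by these compounds, it is also open whether a pyrimidine or a simple phenyl on the carbonyl carbon would show the same dependence.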